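Oxolanyl in place of methyl on the shared core

The compounds below may be only part of what the source reports. "The series", "measured", "known", "first", "only" and "open" are said of these compounds alone.

Measured compounds:
Compound 1 `Cc1cc(C)c(CN2CCc3c(Cl)cc([C@H](CO)[C@H]4CCCO4)c(Cl)c3C2=O)c(=O)[nH]1`: 8 nM
Compound 2 `Cc1cc(C)c(CN2CCc3c(Cl)cc([C@H](C)CO)c(Cl)c3C2=O)c(=O)[nH]1`: 17 nM
Compound 3 `CCOC(c1cc(Cl)c2c(c1Cl)C(=O)N(Cc1c(C)cc(C)[nH]c1=O)CC2)C1CS(=O)(=O)C1`: 460 nM; 2.9 nM (2 entries)

In an assay for inhibition of histone-lysine N-methyltransferase EZH2 variant Y641N (Homo sapiens), read by scintillation counting, with a stated time of 60 min, in the presence of a further agent that is not named here (on this read-out higher numbers stand for weaker inhibition and lower numbers for stronger inhibition), compound 2 gives 17 nM, the highest of the two single numbers, with compound 1 nearest at a step of a 2.1-fold higher number from compound 1 to compound 2 (0.33 log units; beyond the scatter). Compound 3 has no single number, since its repeated entries the several entries of compound 3 in this assay, 460 nM; 2.9 nM (2 entries) disagree widely.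

Compound 4 `Cc1cc(C)c(CN2CCc3c(Cl)cc([C@@H](CO)[C@@H]4CCCO4)c(Cl)c3C2=O)c(=O)[nH]1` differs from compound 2 by oxolan-2-yl in place of methyl on a saturated chain carbon bound to an aromatic carbon and a saturated chain carbon. Among the compounds with values here, the one measured step that bears on this change runs the other way: a 2.1-fold higher number from compound 1 to compound 2 (0.33 log units; beyond the scatter), a modest loss when the larger group was replaced by a smaller one. Compound 4 carries the same oxolanyl group as compound 1 but with the opposite configuration at its two centres, so the step from compound 1 is not a direct guide. On the evidence of the step from compound 1 to compound 2, a modest gain is expected, of about a 1.5-fold lower number from compound 2 to compound 4 (0.19 log units; within the scatter), in this assay. Compound 4 is therefore estimated at 11 nM, within a range of 4 nM to 40 nM.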

Compound 4, inhibition constant: 135 nM
Compound 4: middle estimate off by 12-fold (1.09 log units), on the low side; the whole stated range lies below it.
By their numbers in this assay, from the lowest: compound 1; then compound 2; then compound 4.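

In this assay, oxolan-2-yl in place of methyl on this saturated chain carbon brings (a 7.9-fold higher number from compound 2 to compound 4 (0.90 log units; beyond the scatter)), so the larger group does not by itself give a lower number. The gap between the two oxolanyl compounds (a 17-fold higher number from compound 1 to compound 4 (1.23 log units; beyond the scatter)) can be put down to configuration alone, because of this: the fact that compounds 1 and 4 differ only in the configuration as drawn. The effect of the change at this position therefore depends on how the group is drawn in space: compound 1 has a lower number than compound 2, and compound 4 a higher one.

The compounds shown leave open which of the two inverted stereocentres carries the difference. They also leave open whether a methoxymethyl chain or an oxan-2-yl ring in place of methyl would show the same split between configurations.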